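The source may report more compounds than this note shows. Statements on the series, on what has been measured and on what is new or still open speak of the compounds shown alone.

Compound 2 `Cc1cc2c(-c3ccc(F)cc3)c(/C=C/[C@@H](O)C[C@@H](O)CC(=O)O)c(C(C)C)nc2s1` gives -21.5% in an in vivo functional assay on the whole organism for inhibition of 3-hydroxy-3-methylglutaryl-coenzyme A reductase (Rattus norvegicus), at a dose of 0.2 mg/kg by the oral route (on this read-out higher numbers stand for a stronger effect at the one dose given and lower numbers for a weaker effect), the lowest of the two numbers recorded; its nearest neighbour is compound 1 `CCc1c(C)sc2nc(C(C)C)c(/C=C/[C@@H](O)C[C@@H](O)CC(=O)O)c(-c3ccc(F)cc3)c12`, which in this assay gives 7.9%. Going by the values given here, the one step recorded runs a number 29.4 percentage points lower from compound 1 to compound 2 (beyond the scatter), so removing carbon from the core went with a weaker effect. Compound 3 `CC(C)c1cc2c(-c3ccc(F)cc3)c(/C=C/[C@@H](O)C[C@@H](O)CC(=O)O)c(C(C)C)nc2s1` differs from compound 2 by isopropyl in place of methyl on an aromatic carbon, on the aromatic carbon next to the ring sulfur. Among the compounds with values here, that is a change in the opposite sense to the one recorded step, carbon entering rather than leaving, though at a different place on the core, so the recorded step bears on it only loosely. On that basis a modest rise in this assay is expected for compound 3, and the step is estimated as a number 21.5 percentage points higher from compound 2 to compound 3 (beyond the scatter). The value expected for compound 3 in this assay is 0%, within a range from -25% to 25%.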

Compound 3, a percentage reported as inhibition, in the whole organism at one dose (the size of the read-out at that dose, not a potency): -71.5%
Beside the measured number, compound 3's estimate is 71.5 percentage points above it; measured number outside the range, below it.
By their numbers in this assay, from the lowest: compound 3; then compound 2; then compound 1.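

Isopropyl in place of methyl, on the aromatic carbon next to the ring sulfur, gives a number 50 percentage points lower from compound 2 to compound 3 (beyond the scatter) in this assay. The earlier step, a number 29.4 percentage points lower from compound 1 to compound 2 (beyond the scatter), took carbon away at a different place on the core, whereas this one adds carbon and the number still falls, so across these compounds the read-out does not simply rise with added carbon. Nothing available explains the fall at this position.

From the compounds shown here alone, what remains open is how the read-out runs on this carbon between methyl and isopropyl, for instance with an ethyl group, and whether a hydroxymethyl group or an amine there would bring the number back up. Also open, going by these compounds, is whether this step holds at any dose other than the single one given in this assay.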